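A Sulfonyl Substituent Change on Compound 1

The source may hold more compounds than are shown below. What is called first, only, known or untested is meant among the compounds shown, and "the series" means these compounds.

Of the compounds shown here, three have so far been measured in a functional assay on DU-145 cells (Homo sapiens) for inhibition, read by trypan blue exclusion, with a stated time of 72 h; a lower number here means a stronger inhibitor, a higher number a weaker inhibitor. Compound 1 `Cn1c(=O)c(S(=O)(=O)Cc2ccc(F)cc2)cc2cnc(Nc3ccc4[nH]ccc4c3)nc21` gives 30000 nM in this assay. Compound 2 `Cn1c(=O)c(S(=O)(=O)c2ccc(OC(=O)CCCCC3SCC4NC(=O)NC43)cc2)cc2cnc(Nc3ccc4[nH]ccc4c3)nc21` gives 150 nM, and compound 3 `Cn1c(=O)c(S(=O)(=O)c2ccc(F)cc2F)cc2cnc(Nc3ccncn3)nc21` gives 50000 nM. Among these three numbers compound 1 stands second highest; its nearest neighbour is compound 3, whose value lies within the usual scatter of it, while compound 2 lies far lower, well beyond the scatter. Going by the values given here, no pair of measured compounds differing in a single place is available, so no measured single step can anchor an expectation.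

The unmeasured compound 4 `Cn1c(=O)c(S(=O)(=O)c2ccc(N)cc2F)cc2cnc(Nc3ccc4[nH]ccc4c3)nc21` differs from compound 1 in one place: 4-amino-2-fluorophenyl in place of 4-fluorobenzyl on a sulfonyl sulfur. A ring carried directly on the sulfonyl sulfur is also found in compound 2, and there compound 2 gives 150 nM, whereas compound 3, which carries its ring directly on the sulfonyl sulfur but has a different group on the shared core, gives 50000 nM. With that mixed picture, the step from compound 1 to compound 4 is expected to be a drop toward a lower number, beyond the scatter, a 10-fold lower number from compound 1 to compound 4 (1.00 log units; beyond the scatter). The value expected for compound 4 in this assay is 3000 nM, with a range from 300 nM to 30000 nM.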

Compound 4, half-maximal inhibitory concentration: 8000 nM
Beside the measured number, compound 4's estimate is 2.7-fold (0.43 log units) below it; low and high end bracket the measured number.
By their numbers in this assay, from the lowest: compound 2; then compound 4; then compounds 1 and 3 (each within the scatter of the next).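

In this assay, going by these compounds alone, a single change to compound 1 can now be read directly for the first time: 4-amino-2-fluorophenyl in place of 4-fluorobenzyl on a sulfonyl sulfur gives a 3.8-fold lower number from compound 1 to compound 4 (0.57 log units; beyond the scatter). The step is modest but beyond the scatter, so this position responds to a change of group even though the heavy-atom count stays the same. The entering group counts a hydrogen-bond donor and a hydrogen-bond acceptor where the leaving group counts neither, but no measurement shown here explains why the number falls.

The compounds shown leave open which part of the change carries the step, since the benzyl carbon leaves, an amine enters and the fluorine takes a different place on the ring, all in one move. A 4-fluorophenyl or a 4-aminobenzyl group on the same sulfonyl sulfur of the shared core would begin to separate these parts, and a hydroxyl or a carboxylic acid in place of the amine would test whether the amine itself matters.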